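Swapping the amide ring partner on a shared core

The source may hold more compounds than are shown below. What is called first, only, known or untested is meant among the compounds shown, and "the series" means these compounds.

Measured so far in a physicochemical assay for lipophilicity, at pH 7.4; a lower number here means a more polar compound, a higher number a more lipophilic compound:
Compound 1, `CNC(=O)c1cc(C(=O)NC2CC2)cc2c1O[C@H](CF)[C@H]2c1ccccc1`, gives 3.9.
Compound 2, `CNC(=O)c1cc(C(=O)N[C@H]2CC[C@H](O)CC2)cc2c1OC[C@@]2(C)c1ccccc1`, gives 3.3.
Compound 3, `CNC(=O)c1cc(C(=O)N[C@H]2[C@@H]3COC[C@@H]32)cc2c1OC[C@H]2c1cccc(OC)c1`, gives 3.2.

Compound 2 has the second highest of these three numbers; its gap to compound 3 lies within the scatter, while compound 1 sits beyond the scatter above it.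

Compound 4, `CNC(=O)c1cc(C(=O)NC2CC2)cc2c1OC[C@@]2(C)c1ccccc1`, differs from compound 2 in one place: cyclopropyl in place of 4-hydroxycyclohexyl on an amide-type nitrogen. Among the measured compounds shown here, no measured pair shows this exact change, so its size is estimated from the compounds above. Compound 1 also carries cyclopropyl on an amide-type nitrogen and reads 3.9, which suggests a rise beyond the scatter in this assay.

Compound 4 is therefore expected to give 3.8, estimated between 3.4 and 4.2, an expected step of a number 0.50 log units higher from compound 2 to compound 4 (beyond the scatter).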

Compound 4, distribution coefficient: 4
Compound 4: the middle estimate sits 0.20 log units below what was measured; measured number inside the range.
By their numbers in this assay, from the lowest: compounds 3 and 2 (each within the scatter of the next); then compounds 1 and 4 (each within the scatter of the next).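

Among the compounds shown here, putting cyclopropyl in place of 4-hydroxycyclohexyl on the amide-type nitrogen gives a number 0.70 log units higher from compound 2 to compound 4 (beyond the scatter) in this assay, the first measured pair for any change at this position. The read-out therefore responds to the group on this nitrogen while the rest of the compound stays fixed. No supporting measurement accounts for the step. On these data alone, how much of it follows the hydroxyl and how much the ring remains open, and a plain cyclohexyl or an aminocyclohexyl on the same nitrogen would help separate them. Whether the step carries over to other cores is also unknown.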